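Carbamate for isonicotinoyl on the fully methylated scaffold

This account rests on a few compounds, and the source may have more. Where it says the series, first, only, none or still open, it means among the compounds named here.

Three members of the series have been measured in a physicochemical assay on cells (Homo sapiens), with a stated time of 18 h, tested at 10 uM; a higher number here means a weaker effect of the compound at the concentration tested, a lower number a stronger effect. Compound 1 `COc1cc(/C=N/NC(=O)c2ccncc2)cc(OC)c1O` gives 7% in this assay, compound 2 `COc1cc(/C=N/NC(=O)OCc2ccccc2)cc(OC)c1O` gives 3%, and compound 3 `COc1cc(/C=N/NC(=O)c2ccncc2)cc(OC)c1OC` gives 94%. Compound 3 stands highest of the three numbers: its nearest neighbour is compound 1, and the step of a number 87 percentage points higher from compound 1 to compound 3 (beyond the scatter) is large and beyond the scatter, while compound 2 lies furthest away, also beyond the scatter. The two compounds carrying the free hydroxyl on the aromatic ring sit close together, the step of a number 4 percentage points lower from compound 1 to compound 2 (within the scatter) being within the scatter.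

Compound 4 `COc1cc(/C=N/NC(=O)OCc2ccccc2)cc(OC)c1OC` differs from compound 3 in one place: benzyloxy in place of pyridin-4-yl on a carbonyl carbon. Within the data shown here, the only measured step that bears on this change is the one between compound 1 and compound 2, where the same exchange on the shared core with the free hydroxyl gave a number 4 percentage points lower from compound 1 to compound 2 (within the scatter), a difference within the scatter. Carried over to the methylated core, the expectation for this assay is therefore a step from compound 3 to compound 4 of a number 3 percentage points lower from compound 3 to compound 4 (within the scatter), not beyond the scatter in either direction.

Compound 4 is accordingly estimated to give 91% in this assay, with an expected range from 78% to 100%.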

Compound 4, a percentage reported as activity, at one concentration (the size of the read-out at that concentration, not a potency): 100%
Compound 4: middle estimate off by 9 percentage points, on the low side, within the range that was stated.
By their numbers in this assay, from the lowest: compounds 2 and 1 (each within the scatter of the next); then compounds 3 and 4 (each within the scatter of the next).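

On the core with the methylated oxygen, benzyloxy in place of pyridin-4-yl on a carbonyl carbon gives a number 6 percentage points higher from compound 3 to compound 4 (within the scatter) in this assay, so this exchange now stays within the scatter on both cores shown, not only on the core with the free hydroxyl. Methyl in place of hydrogen on an oxygen on an aromatic ring now has a second reading with benzyloxy on the carbonyl carbon, a number 97 percentage points higher from compound 2 to compound 4 (beyond the scatter), alongside a number 87 percentage points higher from compound 1 to compound 3 (beyond the scatter) with pyridin-4-yl, so the large step does not depend on which of these two groups is present. Across these four compounds, the hydrogen or methyl on that oxygen separates the two pairs while the group on the carbonyl carbon does not, and none of the four goes against this.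

No independent measurement is available to account for the large methyl step or the absence of a step for the carbonyl exchange. As far as these compounds go, it remains open whether an ethyl or acetyl group on that oxygen would give the same result as methyl, and whether a primary amine or a longer alkyl chain on the carbonyl carbon would stay within the scatter as benzyloxy does.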